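One Aryl Swap on an Aromatic Nitrogen

The source may hold more compounds than are shown below. What is called first, only, known or untested is meant among the compounds shown, and "the series" means these compounds.

Compound 1 `N#CC1=C(N)Oc2c(N)cc3nc4ccccc4nc3c2C12C(=O)N(Cc1cnnn1-c1cccc(Br)c1)c1ccccc12` and compound 2 `CCOc1ccc(-n2nncc2CN2C(=O)C3(C(C#N)=C(N)Oc4c(N)cc5nc6ccccc6nc5c43)c3ccccc32)cc1` share one core and differ only in the group carried on an aromatic nitrogen. In a functional assay on HCT-116 cells (Homo sapiens) for antiproliferative activity, read by MTT assay, with a stated time of 48 h (a lower number here means a stronger inhibitor, a higher number a weaker inhibitor), compound 1 gives 26100 nM. Compound 2 reaches only the assay limit of > 50000 nM and has no number. The step of an at least 1.9-fold higher number from compound 1 to compound 2 (0.28 log units; that floor lies within the scatter) is thus a floor, set by the limit of > 50000 nM in this assay, at which 1 of the 2 values shown sits. Compound 3 `COc1ccc(OC)c(-n2nncc2CN2C(=O)C3(C(C#N)=C(N)Oc4c(N)cc5nc6ccccc6nc5c43)c3ccccc32)c1` carries 2,5-dimethoxyphenyl in place of 4-ethoxyphenyl on an aromatic nitrogen. Among the compounds with values here, only that one measured step bears on this change, and it ended at the limit, so no step beyond the scatter is expected. The estimate for compound 3 is 50000 nM, between 20000 nM and 100000 nM. That expected step is a number no higher from compound 2 to compound 3 (the limit leaves the size open).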

Compound 3, half-maximal inhibitory concentration: > 50000 nM
Compound 3: a limit, no number; the forecaster's own chance of this, stated with the estimate: 60%; the middle value sits exactly at the limit.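

Compound 3 also gives a limit of the assay and not a number, so 2,5-dimethoxyphenyl joins 4-ethoxyphenyl at that limit in this assay and the step between these two compounds cannot be read. The step of an at least 1.9-fold higher number from compound 1 to compound 3 (0.28 log units; that floor lies within the scatter) is again only a floor, so neither group is yet shown to differ from 3-bromophenyl. One thing caps the reading: the limit of > 50000 nM in this assay, at which 2 of the 3 values shown sit.

Still open, on these data alone, is how a phenyl ring carrying an amine or a carboxylic acid would read on this nitrogen, or a longer alkyl chain in place of the ring. As far as these compounds go, whether any such group would give a clearly lower number than the 3-bromophenyl group of compound 1 also remains unknown.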